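From Cyclohexyl to tert-Butyl: Compound 1 to Compound 4

A few compounds are considered here, and "the series" means these few. Any claim that something is new, unique, unknown or untested is made for them only; others in the source may bear on it.

Three compounds have been measured in an assay on cells with melanin-concentrating hormone receptor 1 (Homo sapiens) as the target, read by radioligand binding; on this read-out higher numbers stand for weaker inhibition and lower numbers for stronger inhibition:

compound 1 `Nc1ccc2cccc(OCCC3CCCCC3)c2n1`: 808 nM
compound 2 `CC(CC(C)(C)C)Oc1cccc2ccc(N3CCCCC3)nc12`: > 2000 nM
compound 3 `CC(CC(C)(C)C)Oc1cccc2ccc(N(C)C)nc12`: > 2000 nM

For the measured compounds named here, compound 1 stands alone as the only actual number among the three values. For compound 2 the value is a limit of the assay, not a number. For compound 3 the value is likewise a limit (the limit of > 2000 nM in this assay, at which 2 of the 3 values shown sit). Going by the values given here, the one step between measured compounds, a step that the two limits leave unreadable from compound 2 to compound 3, replaces one amine with another on the aromatic carbon and cannot be read, since both ends sit at the limit.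

Compound 4 `CC(C)(C)CCOc1cccc2ccc(N)nc12` keeps the primary amine of compound 1 and differs from it only at the ether chain: tert-butyl in place of cyclohexyl on a saturated chain carbon, two bonds along the chain from an oxygen on an aromatic ring. Among the compounds with values here, no measured step touches this place, so nothing among the measured compounds gives the size of this change directly; the unreadable step from compound 2 to compound 3 concerns the amine, not the chain. Compound 4 is therefore expected to lose a little against compound 1, the estimated step being a 1.9-fold higher number from compound 1 to compound 4 (0.27 log units; within the scatter), though within the usual scatter a step of no size is also possible. For compound 4 the estimate is 1500 nM, with a range from 500 nM to 4000 nM.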

Compound 4, half-maximal inhibitory concentration: 201 nM
Beside the measured number, compound 4's estimate is 7.5-fold (0.87 log units) above it, outside the stated range (below it).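

In this assay, for the compounds shown here, the end of the ether chain proves to be a place where the reading moves, and this is the first step among the compounds that can be read: tert-butyl in place of cyclohexyl gives a 4.0-fold lower number from compound 1 to compound 4 (0.60 log units; beyond the scatter). With the primary amine unchanged, it shows that the six-membered ring of carbon is not needed at this place, since tert-butyl, with no ring and fewer heavy atoms, gives the lower number. Nothing given here bears on why the number falls at this change.

As far as these compounds go, the step from compound 2 to compound 3 cannot be read, as both values are limits of the assay, so it remains open whether the chain change would carry over to those substituted amines. Also open, from the compounds shown here alone, is how a phenyl ring, a cyclopentyl group or a longer chain would read at this place.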